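The source may hold more compounds than are shown below. What is called first, only, known or untested is meant among the compounds shown, and "the series" means these compounds.

Compound 1 `CC(O)(C(=O)Nc1ccc(S(=O)(=O)c2ccccc2)c(C#N)c1)C(F)(F)F` and compound 2 `CC(O)(C(=O)Nc1ccc(C#N)c(S(=O)(=O)c2ccccc2)c1)C(F)(F)F` are built from the same atoms joined differently; the difference between the two cores is not broken down here. In a functional assay (Cavia porcellus) with sulfonylurea receptors; K-ATP channels (Homo sapiens) as the target (a lower number here means a stronger inhibitor, a higher number a weaker inhibitor), compound 1 gives 3800 nM. In this assay compound 2 gives 2600 nM. Compound 3 `CC(O)(C(=O)Nc1ccc(S(=O)(=O)c2ccccc2)c([N+](=O)[O-])c1)C(F)(F)F` differs from compound 1 by nitro in place of cyano on an aromatic carbon. In this assay compound 3 reaches only a limit, > 30000 nM. The step is an at least 7.8-fold higher number from compound 1 to compound 3 (0.89 log units; beyond the scatter), and it is known only as a lower bound because the limit of > 30000 nM in this assay, at which 1 of the 3 values shown sits, is where compound 3 sits. Compound 4 `CC(O)(C(=O)Nc1ccc([N+](=O)[O-])c(S(=O)(=O)c2ccccc2)c1)C(F)(F)F` carries the same kind of change from compound 2, namely (nitro in place of cyano on an aromatic carbon); the place differs in being para rather than meta to a large group. The expected step is a 9.6-fold higher number from compound 2 to compound 4 (0.98 log units; beyond the scatter), resting on the step from compound 1 to compound 3. For compound 4 the expected value is 25000 nM, between 9000 nM and 60000 nM.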

Compound 4, half-maximal inhibitory concentration: > 30000 nM
Compound 4: a limit, no number (the forecaster's own chance of this, stated with the estimate: 45%); middle value at least 1.2-fold (0.07 log units) away from the limit.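

In this assay compound 4 reaches only a limit, > 30000 nM. Putting nitro in place of cyano on this core gives an at least 11-fold higher number from compound 2 to compound 4 (1.06 log units; beyond the scatter), so the weakening seen on the core of compound 1 also appears on the core of compound 2, and the two steps point the same way: the same change on two cores in this assay, an at least 7.8-fold higher number (0.89 log units; beyond the scatter) from compound 1 to compound 3 and an at least 11-fold higher number (1.06 log units; beyond the scatter) from compound 2 to compound 4; the limit leaves it open whether they differ. As far as these compounds go, the true size of either step remains unknown, since each is only a lower bound and both nitro compounds sit at the same limit: the limit of > 30000 nM in this assay, at which 2 of the 4 values shown sit.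

The compounds shown carry only cyano or nitro at this place, so it stays open how an amine or a carboxylic acid there would behave in this assay. From the compounds shown here alone, it also stays open what a longer chain in place of the phenyl of the phenylsulfonyl group would do.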